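The source may report more compounds than this note shows. Statements on the series, on what has been measured and on what is new or still open speak of the compounds shown alone.

Compound 2 `O=C1C=C(Nc2ccccc2F)C(=O)c2c1nc1n2[C@H]2OC[C@@H](O)[C@H]2OC1` is the starting point. In a functional assay on ECa-109 cells for inhibition, with ECa-109 cell line (Homo sapiens) as the target, read by sulforhodamine B assay (on this read-out higher numbers stand for weaker inhibition and lower numbers for stronger inhibition), compound 2 gives 2760 nM, the highest of the two plain numbers in this set. Compound 3 `O=C1C(Nc2ccc(C(F)(F)F)cc2)=CC(=O)c2c1nc1n2[C@H]2OC[C@@H](O)[C@H]2OC1` gives 2250 nM, a gap within the usual scatter. Compound 1 `CCc1ccc(NC2=CC(=O)c3c(nc4n3[C@H]3OC[C@@H](O)[C@H]3OC4)C2=O)cc1` gives only a limit, > 4000 nM, so its value is not a number. The change to compound 4 `Cc1ccc(NC2=CC(=O)c3nc4n(c3C2=O)[C@H]2OC[C@@H](O)[C@H]2OC4)cc1` is 4-methylphenyl in place of 2-fluorophenyl on an amine nitrogen. Within the data shown here, no measured step matches it exactly; the closest is an at least 1.7-fold lower number from compound 1 to compound 3 (0.24 log units; that floor lies within the scatter), and that step is bounded by the limit of > 4000 nM in this assay, at which 1 of the 3 values shown sits. A methyl group is nearer to ethyl than to trifluoromethyl, so a weaker result than compound 2 is expected, and compound 4 is estimated at 4000 nM, between 2000 nM and 8000 nM. The expected step is a 1.4-fold higher number from compound 2 to compound 4 (0.16 log units; within the scatter).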

Compound 4, half-maximal inhibitory concentration: 3480 nM
For compound 4 the middle estimate is 1.1-fold (0.06 log units) above the measured one, within the range that was stated.
By their numbers in this assay, from the lowest: compounds 3, 2 and 4 (each within the scatter of the next). At a limit, above all of these: compound 1.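

Putting 4-methylphenyl in place of 2-fluorophenyl on the amine nitrogen gives a 1.3-fold higher number from compound 2 to compound 4 (0.10 log units; within the scatter) in this assay. Among these compounds, this is the first step here with plain numbers at both ends, and it shows that these two aromatic groups cannot be told apart in this assay. Compound 1 stands only as a limit and cannot be placed against this pair: the limit of > 4000 nM in this assay, at which 1 of the 4 values shown sits.

Still open, going by these compounds, is whether an amine or a carboxylic acid on the aromatic ring, or a longer chain in its place, would give a step beyond the scatter.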